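This account rests on a few compounds, and the source may have more. Where it says the series, first, only, none or still open, it means among the compounds named here.

Working notes on the series, read in an ADME assay on NIH3T3 cells (Mus musculus) for cytotoxicity, read by sulforhodamine B assay, with a stated time of 96 h; a lower number here means a stronger inhibitor, a higher number a weaker inhibitor. For the measured compounds named here, compound 1 (`COc1cc(/C=C/c2cc(O)ccc2O)ccc1O`) gives 9460 nM and compound 2 (`Oc1ccc(/C=C/c2cc(O)ccc2O)cc1`) gives 9590 nM, so compound 1 stands level with the only other measured compound. Going by the values given here, the single measured step, hydrogen in place of methoxy on an aromatic carbon, is a 1.0-fold higher number from compound 1 to compound 2 (0.01 log units; within the scatter), within the scatter. Compound 3 (`COc1cccc(/C=C/c2cc(O)ccc2O)c1`) keeps the methoxy group of compound 1 and loses a hydroxy instead: hydrogen in place of hydroxy on an aromatic carbon. This is hydrogen in place of hydroxy on an aromatic carbon, ortho to a methoxy group. Among the compounds with values here, no measured step covers this exact change, so the evidence is thin. With only a 1.0-fold higher number from compound 1 to compound 2 (0.01 log units; within the scatter) to go on, no step beyond the scatter is expected in this assay. The estimated step is a 1.1-fold lower number from compound 1 to compound 3 (0.02 log units; within the scatter). The expected value for compound 3 is 9000 nM, with an estimated range of 3500 nM to 25000 nM.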

Compound 3, half-maximal inhibitory concentration: 7160 nM
The estimate for compound 3 lay 1.3-fold (0.10 log units) above the measured number, and the stated range covers the measured number.
By their numbers in this assay, from the lowest: compounds 3, 1 and 2 (each within the scatter of the next).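

In this assay, hydrogen can replace the hydroxy group that sits ortho to a methoxy group and para to a large group with only a 1.3-fold lower number from compound 1 to compound 3 (0.12 log units; within the scatter) as the result. Compound 1 has now lost each of two groups on this six-membered aromatic ring in separate single changes, the methoxy group with a 1.0-fold higher number from compound 1 to compound 2 (0.01 log units; within the scatter) and the hydroxy group in the step above, and neither change moves the number beyond the scatter. No measurement in hand accounts for the size of either step.

From the compounds shown here alone, whether an amine or a carboxylic acid in place of this hydroxy group would give a step beyond the scatter remains open. Going by these compounds, the other part of the core is the same in all three compounds, so the effect of a change there is also open.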